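A few compounds are considered here, and "the series" means these few. Any claim that something is new, unique, unknown or untested is made for them only; others in the source may bear on it.

Measured compounds:
- compound 1, `Cc1cc(OCCCCCCC[N+]23CCN(CC2)CC3)cc(-n2cc(C(=O)Nc3cc(F)cc(F)c3)c(=O)c3ccc(N(C)C)nc32)c1`: 5.52%
- compound 2, `Cc1cc(-n2cc(C(=O)Nc3cc(F)cc(F)c3)c(=O)c3ccc(N(C)C)nc32)ccc1OCCCCCCC[N+]1(C)CCCC1`: 35.9%
- compound 3, `Cc1ccc(-n2cc(C(=O)Nc3cc(F)cc(F)c3)c(=O)c3ccc(N(C)C)nc32)cc1OCCCCCCC[N+]1(C)CCCCC1`: 45.1%

In an assay on LX2 cells for inhibition of COL1A1 promoter (Homo sapiens), read by a luciferase reporter, with a stated time of 24 h, tested at 50 uM (a higher number here means a stronger effect of the compound at the concentration tested, a lower number a weaker effect), compound 1 gives 5.52%, the lowest of the three numbers. Its nearest neighbour is compound 2, which gives 35.9%, a gap beyond the scatter; the furthest is compound 3, which gives 45.1%, also beyond the scatter. Among the compounds with values here, compounds 2 and 3 carry a single charged ring at the end of the chain, while compound 1 carries the bridged pair of rings, but no pair of them differs in only one place, so these three values alone show the spread.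

Compound 4, `Cc1cc(OCCCCCCC[N+]2(C)CCN(C)CC2)cc(-n2cc(C(=O)Nc3cc(F)cc(F)c3)c(=O)c3ccc(N(C)C)nc32)c1`, has not been measured. It differs from compound 1 in one place:

a group of 8 heavy atoms (6 carbon, 2 nitrogen; one six-membered non-aromatic ring with 2 hetero atoms) in place of a group of 8 heavy atoms (6 carbon, 2 nitrogen; 2 six-membered non-aromatic rings with 2 hetero atoms each), on a saturated chain carbon, seven bonds along the chain from an oxygen on an aromatic ring

Within the data shown here, no step between measured compounds covers this change, so the expectation rests on the other two compounds, whose single charged rings sit higher than compound 1. The step from compound 1 to compound 4 is expected to be a number 14.5 percentage points higher from compound 1 to compound 4 (beyond the scatter) in this assay, a rise of modest size, though it could remain within the scatter. Compound 4 is estimated at 20%, within a range of 0% to 42%.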

Compound 4, a percentage reported as inhibition, at one concentration (the size of the read-out at that concentration, not a potency): 38.2%
Beside the measured number, compound 4's estimate is 18.2 percentage points below it; low and high end bracket the measured number.
By their numbers in this assay, from the lowest: compound 1; then compounds 2, 4 and 3 (each within the scatter of the next).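

In this assay, replacing the 2 six-membered non-aromatic rings with 2 hetero atoms each by one six-membered non-aromatic ring with 2 hetero atoms gives a number 32.7 percentage points higher from compound 1 to compound 4 (beyond the scatter), a large step. Both end groups have 8 heavy atoms (6 carbon, 2 nitrogen), 0 hydrogen-bond donors, 1 hydrogen-bond acceptor and a net charge of +1, so the step comes with a change in the ring system that none of these counts registers. Within the data shown here, this pair differs in one place only, and it ties the low number of compound 1 to its end group on a saturated chain carbon, seven bonds along the chain from an oxygen on an aromatic ring, which the earlier compounds could not do.

On these data alone, it remains open whether other end groups at this position, such as a morpholine ring or an open-chain trimethylammonium group, or a longer chain carrying the same ring, would give a similar number. Nothing in the data shown accounts for the size of this step.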